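Shifting the Hydroxyl on the Aryl Group

The compounds below may be only part of what the source reports. "The series", "measured", "known", "first", "only" and "open" are said of these compounds alone.

Compound 3 `CCCSc1nc(N/N=C(\C)c2ccc(O)cc2)c2nnn(Cc3ccccc3)c2n1` gives 21600 nM in a functional assay on MCF7 cells (Homo sapiens) for antiproliferative activity, read by MTT assay, with a stated time of 72 h (a higher number here means a weaker inhibitor, a lower number a stronger inhibitor), the lowest of the three numbers, though its distance to compound 1 lies within the scatter. Compound 1 `CCCSc1nc(N/N=C(\C)c2ccccc2O)c2nnn(Cc3ccco3)c2n1` gives 29000 nM and compound 2 `CCCSc1nc(N/N=C/c2cccnc2)c2nnn(Cc3ccccc3)c2n1` gives 58700 nM. Among the measured compounds shown here, the only measured single-point step, a 2.7-fold lower number from compound 2 to compound 3 (0.43 log units; beyond the scatter), concerns the group on the carbon with a double bond to nitrogen. Compound 4 `CCCSc1nc(N/N=C(\C)c2ccccc2O)c2nnn(Cc3ccccc3)c2n1` differs from compound 3 by 2-hydroxyphenyl in place of 4-hydroxyphenyl on a carbon with a double bond to nitrogen. For the measured compounds named here, no measured step bears directly on this change. Compound 1 carries the same 2-hydroxyphenyl group on an otherwise different core, and its value sits within the scatter of compound 3, so no step beyond the scatter is expected for a 1.3-fold higher number from compound 3 to compound 4 (0.10 log units; within the scatter). Compound 4 is therefore estimated at 27000 nM, ranging from 12000 nM to 60000 nM.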

Compound 4, half-maximal inhibitory concentration: 11000 nM
Compound 4: the middle estimate sits 2.5-fold (0.39 log units) above what was measured; measured number below the stated range.
By their numbers in this assay, from the lowest: compounds 4, 3 and 1 (each within the scatter of the next, the first and the last beyond it); then compound 2.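

On the carbon with a double bond to nitrogen, 2-hydroxyphenyl in place of 4-hydroxyphenyl gives a 2.0-fold lower number from compound 3 to compound 4 (0.29 log units; within the scatter) in this assay and so does not separate the two hydroxyl placements. Replacing the group of compound 2 gives a 5.3-fold lower number from compound 2 to compound 4 (0.73 log units; beyond the scatter) while phenyl in place of furan-2-yl on a saturated chain carbon bound to an aromatic nitrogen gives a 2.6-fold lower number from compound 1 to compound 4 (0.42 log units; beyond the scatter) as the only step shown at that position. Nothing at hand explains these steps.

The compounds shown leave open how an amine in place of the hydroxyl would read. They also leave open how a cyclohexyl group in place of phenyl on that saturated chain carbon would read.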